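Swapping the Dichlorophenyl Arm for a Fluoro-Methylphenyl

The source may hold more compounds than are shown below. What is called first, only, known or untested is meant among the compounds shown, and "the series" means these compounds.

Measured so far:
- compound 1, `C=CCn1c(=O)/c(=C\c2cccc(Cl)c2)[nH]c(=O)/c1=C\c1ccccc1OC`, gives 4900 nM in a functional assay on MOLT-4 cells (Homo sapiens) for cytotoxicity, read by CCK-8 assay, with a stated time of 72 h; a lower number here means a stronger inhibitor, a higher number a weaker inhibitor
- compound 2, `C=CCn1c(=O)/c(=C\c2cccc(Cl)c2Cl)[nH]c(=O)/c1=C\c1ccccc1OC`, gives 1200 nM
- compound 3, `COc1ccccc1/C=c1\c(=O)[nH]/c(=C/c2cccc(Cl)c2Cl)c(=O)n1C`, gives "not determined" (no result reported)
- compound 4, `C=CCn1c(=O)/c(=C\c2cc(F)ccc2C)[nH]c(=O)/c1=C\c1ccccc1OC`, has not yet been measured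

Going by the values given here, compound 2 holds the lowest number among the two compounds with a value; its nearest neighbour is compound 1, and the single step between them, a 4.1-fold lower number from compound 1 to compound 2 (0.61 log units; beyond the scatter), comes from a chloro in place of a hydrogen on an aromatic carbon. Compound 4 departs from compound 2 by 5-fluoro-2-methylphenyl in place of 2,3-dichlorophenyl on a double-bonded chain carbon bound to an aromatic carbon. Among the compounds with values here, no measured pair shows this exchange of one aromatic arm for another, so the one step recorded bears on it only loosely: it shows that changing the substituents on this arm can move the number beyond the scatter. Within the data shown here, because the only recorded step, a 4.1-fold lower number from compound 1 to compound 2 (0.61 log units; beyond the scatter), does not cover this exchange of arms, the expected step of a 2.5-fold higher number from compound 2 to compound 4 (0.40 log units; beyond the scatter) is modest and uncertain, leaning toward a higher number. Compound 4 is therefore estimated at 3000 nM, within 1000 nM to 10000 nM.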

Compound 4, half-maximal inhibitory concentration: 3800 nM
Compound 4: the middle estimate sits 1.3-fold (0.10 log units) below what was measured; the range from low to high includes it.
By their numbers in this assay, from the lowest: compound 2; then compounds 4 and 1 (each within the scatter of the next).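

In this assay, the arm on the double-bonded chain carbon proves sensitive to more than the number of substituents it carries: 5-fluoro-2-methylphenyl in place of 2,3-dichlorophenyl gives a 3.2-fold higher number from compound 2 to compound 4 (0.50 log units; beyond the scatter). Set against the 3-chlorophenyl arm, the same exchange gives a 1.3-fold lower number from compound 1 to compound 4 (0.11 log units; within the scatter), so among these three compounds, the lower number of compound 2 stays with the 2,3-dichlorophenyl arm and does not carry over to this other arm with two substituents. No measurement shown here explains the difference between these arms.

Whether the step comes from the fluoro group, the methyl group or the loss of the chlorines remains open, as no arm shown carries fluoro or methyl alone. From the compounds shown here alone, how an arm bearing an amine or a carboxylic acid would behave also remains open.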